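A few compounds are considered here, and "the series" means these few. Any claim that something is new, unique, unknown or untested is made for them only; others in the source may bear on it.

Compound 1 `CN1CC(NC(=O)c2ccncc2Nc2cc(-c3ccc4ccn(C)c4c3)c3nccnc3c2)C1` and compound 2 `CN1CCC(CNC(=O)c2ccncc2Nc2cc(-c3ccc4ccn(C)c4c3)c3nccnc3c2)C1` share one core and differ only in the group on the amide-type nitrogen. In an assay on lysate for inhibition of 6-phosphofructo-2-kinase/fructose-2,6-bisphosphatase 3 (Homo sapiens), with stated times of 0.5 min and 45 min (on this read-out higher numbers stand for weaker inhibition and lower numbers for stronger inhibition), compound 1 gives 9190 nM, and in this assay compound 2 gives 24000 nM, the highest of the two numbers recorded; the step of a 2.6-fold higher number from compound 1 to compound 2 (0.42 log units; beyond the scatter) is described as modest but beyond the scatter. Compound 3 `CC(=O)N1CCC(NC(=O)c2ccncc2Nc2cc(-c3ccc4ccn(C)c4c3)c3nccnc3c2)C1` is the next member, made from compound 2 by the change (1-acetylpyrrolidin-3-yl in place of (1-methylpyrrolidin-3-yl)methyl on an amide-type nitrogen). For the measured compounds named here, the only measured step that bears on it is the one from compound 1 to compound 2, which also alters the group on that same amide-type nitrogen, and compound 3 returns to a ring carbon attached straight to the nitrogen as in compound 1. Going by the values given here, no measured pair speaks to the acetyl in place of the methyl on the ring nitrogen. Compound 3 is therefore expected to show a step of a 2.4-fold lower number from compound 2 to compound 3 (0.38 log units; beyond the scatter), with an estimated value of 10000 nM in a range from 3000 nM to 35000 nM.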

Compound 3, half-maximal inhibitory concentration: > 100000 nM
Compound 3: a limit, no number (the forecaster's own chance of this, stated with the estimate: 15%); middle value at least 10-fold (1.00 log units) away from the limit.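

In this assay compound 3 gives a limit and not a number: the limit of > 100000 nM in this assay, at which 1 of the 3 values shown sits.

The group on the amide-type nitrogen therefore carries more weight than the modest 2.6-fold higher number from compound 1 to compound 2 (0.42 log units; beyond the scatter) suggested, since the 1-acetylpyrrolidin-3-yl group brings an at least 4.1-fold higher number from compound 2 to compound 3 (0.61 log units; beyond the scatter) and a large at least 10-fold higher number from compound 1 to compound 3 (1.03 log units; beyond the scatter). Restoring a ring carbon attached straight to that nitrogen did not keep the number near that of the 1-methylazetidin-3-yl group, so the attachment alone does not set the level in this short series of three compounds.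

From the compounds shown here alone, it remains open how a 1-methylpyrrolidin-3-yl group on the same nitrogen would read, a comparison that would separate the acetyl from the methyl on the ring nitrogen. Going by these compounds, it is equally open whether an unsubstituted ring amine or a methylsulfonyl group there would sit nearer compound 1 or compound 3.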